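The compounds below may be only part of what the source reports. "The series", "measured", "known", "first", "only" and "open" are said of these compounds alone.

Measured so far in a functional assay on CCRF-CEM cells (Homo sapiens) for cytotoxicity; on this read-out higher numbers stand for weaker inhibition and lower numbers for stronger inhibition:
compound 1 `Nc1ccn([C@H]2CC(F)(F)[C@H](CO)O2)c(=O)n1` gives > 100000 nM, a limit of the assay.
compound 2 `Nc1nc(=O)n([C@H]2CC(F)(F)[C@H](CO)O2)cc1F` gives > 100000 nM, also a limit of the assay.
compound 3 `Nc1ccn([C@@H]2C=C(F)[C@H](CO)O2)c(=O)n1` gives > 100000 nM, again a limit of the assay.

The change from compound 1 to compound 2 is fluoro in place of hydrogen on an aromatic carbon. Its size, a step that the two limits leave unreadable from compound 1 to compound 2, cannot be read, since both values sit at the limit of > 100000 nM in this assay, at which 3 of the 3 values shown sit. Compound 4 `Nc1nc(=O)n([C@@H]2C=C(F)[C@H](CO)O2)cc1F` remains to be measured. The change from compound 3 to compound 4 is fluoro in place of hydrogen on an aromatic carbon; this is the same kind of change as from compound 1 to compound 2, differing around the place only in that the group meta to it counts 8 heavy atoms rather than 9. How the core of compound 3 differs from the core of compound 1 is not broken down here. The expectation for compound 4 rests on compound 3, whose value > 100000 nM is a limit of the assay. The step from compound 3 to compound 4 is expected to be a step that the limit leaves unreadable from compound 3 to compound 4. Compound 4 is estimated at 150000 nM, most likely reported as a limit once more.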

Compound 4, half-maximal inhibitory concentration: > 100000 nM
Compound 4: no number, only a limit; the forecaster's own chance of this, stated with the estimate: 85%; the middle value is on the limit's open side.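

No new step can be read from compound 3 to compound 4, as each gives only a limit: the limit of > 100000 nM in this assay, at which 4 of the 4 values shown sit.

The compounds shown leave open how much fluoro in place of hydrogen, or the difference between the core of compound 1 and the core of compound 3, matters in this assay.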